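Piperazine N-methyl analogues in the chemokine receptor calcium-flux series

A few compounds are considered here, and "the series" means these few. Any claim that something is new, unique, unknown or untested is made for them only; others in the source may bear on it.

Compound 1 `C[C@@H]1CN(c2cccc3c2C[C@H](CN(C)[C@H]2CCCc4cccnc42)NC3)C[C@H](C)N1` — in a functional assay on CCRF-CEM cells for agonist activity at C-X-C chemokine receptor type 4 (Homo sapiens), read by calcium flux, with a stated time of 25 min (on this read-out lower numbers stand for an effect already at smaller amounts and higher numbers for an effect only at larger amounts of compound), compound 1 gives > 30000 nM, a limit of the assay.
Compound 2 `CN(C[C@H]1Cc2c(cccc2N2CCN3CCC[C@@H]3C2)CN1)[C@H]1CCCc2cccnc21` — in this assay compound 2 gives > 30000 nM, a limit of the assay.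
Compound 3 `CCCN(C[C@H]1Cc2c(cccc2N2CCNCC2)CN1)[C@H]1CCCc2cccnc21` — in this assay compound 3 gives > 30000 nM, a limit of the assay.

Compound 1 stands at a limit only, as do both other measured compounds; all three sit at the limit of > 30000 nM in this assay, at which 3 of the 3 values shown sit. Among the compounds with values here, the one measured pair differing in one place, from compound 1 to compound 2, gives a step that the two limits leave unreadable from compound 1 to compound 2, so no readable step size exists.

Compound 4 `CN(C[C@H]1Cc2c(cccc2N2CCNCC2)CN1)[C@H]1CCCc2cccnc21` differs from compound 1 by piperazin-1-yl in place of 3,5-dimethylpiperazin-1-yl on an aromatic carbon. Within the data shown here, no measured step bears readably on this change. Given that compound 1 sits at the limit of > 30000 nM in this assay, at which 3 of the 3 values shown sit, compound 4 is expected to remain at the limit, with a step that the limit leaves unreadable from compound 1 to compound 4 not readable.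

Compound 4 is therefore estimated at 40000 nM, within 15000 nM to 100000 nM.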

Compound 4, half-maximal effective concentration: > 30000 nM
Compound 4: no number, only a limit (the forecaster's own chance of this, stated with the estimate: 90%); the middle value does not contradict the limit.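

Compound 4, like compound 1, compound 2 and compound 3, stands only at a limit, so none of its steps to them can be read: the limit of > 30000 nM in this assay, at which 4 of the 4 values shown sit.

The compounds shown leave open whether any of these group changes alters the response in this assay.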